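The source may hold more compounds than are shown below. What is called first, only, known or untested is meant among the compounds shown, and "the series" means these compounds.

Of the compounds shown here, two built on a shared core have been measured in a functional assay on PC-3 cells (Homo sapiens) for inhibition, read by MTT assay, with a stated time of 72 h; a lower number here means a stronger inhibitor, a higher number a weaker inhibitor. Compound 1 `C#CCSc1nc(Nc2ccc(C)cc2)c2ccncc2n1` carries a methyl group on its aniline ring, and in this assay compound 1 gives 15700 nM. Compound 2 `C#CCSc1nc(Nc2ccccc2OC)c2ccncc2n1` carries a methoxy group on that ring instead. Its reading in this assay is a limit of the assay rather than a number: compound 2 gives > 80000 nM. Compound 2 therefore stands at the limit of > 80000 nM in this assay, at which 1 of the 2 values shown sits, with no finite value to place it against compound 1.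

Compound 3 `C#CCSc1nc(Nc2ccccc2O)c2ccncc2n1` differs from compound 2 in a single place: hydrogen in place of methyl on an oxygen on an aromatic ring. Going by the values given here, no pair of measured compounds shows this change, so its size in this assay is open. Since compound 2 offers only a limit, the step from it is expected to be small and uncertain, and a reading at the limit again would not be surprising. Compound 3 is expected to give roughly 50000 nM in this assay, within a range from 12000 nM to 200000 nM. The step this implies, an at least 1.6-fold lower number from compound 2 to compound 3 (0.20 log units; that floor lies within the scatter), is expected to lean toward a somewhat stronger inhibitor.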

Compound 3, half-maximal inhibitory concentration: 18700 nM
For compound 3 the middle estimate is 2.7-fold (0.43 log units) above the measured one; the measured number falls inside the stated range.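

In this assay, as far as these compounds go, the change from methoxy to hydroxy on an oxygen on an aromatic ring gives an at least 4.2-fold lower number from compound 2 to compound 3 (0.63 log units; beyond the scatter), so replacing this single methyl with hydrogen leaves a step beyond the usual scatter, whose full size remains unknown. Compound 2 gives only a limit of the assay and not a number: the limit of > 80000 nM in this assay, at which 1 of the 3 values shown sits. The replacement of 4-methylphenyl by 2-hydroxyphenyl on a nitrogen on an aromatic ring gives a 1.2-fold higher number from compound 1 to compound 3 (0.08 log units; within the scatter), so compound 1 and compound 3 cannot be told apart here, although the two groups differ both in kind and in where they sit on the ring.

The compounds shown leave open whether a hydroxy group in the 4-position, or a methyl group in the 2-position, would read like compound 3, and therefore what the group and its place each contribute. From the compounds shown here alone, it also remains open what an amine in place of the hydroxy, or a longer chain such as ethoxy on that oxygen, would give in this assay.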